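Swapping isobutyl for sec-butyl in compound 2

This account rests on a few compounds, and the source may have more. Where it says the series, first, only, none or still open, it means among the compounds named here.

Measured so far:
compound 1 `CCC(C)NC(=C\C(=O)/C=C/c1ccc(O)c(OC)c1)/C=C/c1ccc(O)c(OC)c1`: > 25000 nM (a limit)
compound 2 `CC(C)CNC(=C\C(=O)/C=C/c1ccc(O)cc1)/C=C/c1ccc(O)cc1`: 18500 nM
compound 3 `COc1cc(/C=C/C(=O)/C=C(/C=C/c2ccc(OC(C)=O)c(OC)c2)NCC(C)C)ccc1OC(C)=O`: > 25000 nM (a limit)

All three compounds were tested in a functional assay on Caco-2 cells (Homo sapiens) for inhibition, read by sulforhodamine B assay, with a stated time of 72 h (on this read-out lower numbers stand for stronger inhibition and higher numbers for weaker inhibition), and their results differ in kind. Compound 1 returned only a limit (> 25000 nM) and not a number. Compound 3 likewise returned only a limit (> 25000 nM) and not a number. Among the measured compounds shown here, compound 2 (18500 nM) therefore holds the only true number in this small set.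

Compound 4 `CCC(C)NC(=C\C(=O)/C=C/c1ccc(O)cc1)/C=C/c1ccc(O)cc1` has not yet been measured. It is compound 2 with sec-butyl in place of isobutyl on an amine nitrogen, and the two have the same atoms, joined differently: sec-butyl in place of isobutyl on an amine nitrogen. For the measured compounds named here, no measured pair here shows this kind of change, so the size of the step has to be judged. Compound 1 also carries sec-butyl, but its core differs from that of compound 4, so it offers little guidance.

Starting from compound 2 (18500 nM), the expectation in this assay is no step beyond the scatter. The estimated change is a 1.0-fold lower number from compound 2 to compound 4 (0.01 log units; within the scatter) and is expected to be small. In view of the limit of > 25000 nM in this assay, at which 2 of the 3 values shown sit, a plain limit is also possible for compound 4. For compound 4 the estimated value is 18000 nM with an expected range from 10000 nM to 25000 nM when it is measured.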

Compound 4, half-maximal inhibitory concentration: 5800 nM
The estimate for compound 4 lay 3.1-fold (0.49 log units) above the measured number, and the stated range ends above it.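

In this assay, changing isobutyl to sec-butyl on an amine nitrogen whose other neighbour is the double-bonded chain carbon gives a 3.2-fold lower number from compound 2 to compound 4 (0.50 log units; beyond the scatter). The two groups have the same atoms, joined differently, and the same count of four carbons, so this position distinguishes between two arrangements of one butyl chain: the carbon count alone does not fix the result here. The change also moves the series further from the top of the tested range, and compound 4 joins compound 2 in giving a true number in a small set where limits are common: the limit of > 25000 nM in this assay, at which 2 of the 4 values shown sit.

The compounds shown leave open whether a longer chain such as n-pentyl, a ring such as cyclohexyl or a smaller group such as isopropyl on the same nitrogen would lower the number further, and they give no way to say why sec-butyl differs from isobutyl. They also leave open whether this swap would give a similar step on another core, as the cores of compound 1 and compound 3 differ from that of compound 4 and neither compound forms a one-place pair with it.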